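This account rests on a few compounds, and the source may have more. Where it says the series, first, only, none or still open, it means among the compounds named here.

The question here is whether two closely related pairs of compounds harm human lung fibroblast cells in culture, as judged by an ADME assay on MRC5 cells (Homo sapiens) for cytotoxicity, read by fluorescence, with a stated time of 72 h; on this read-out lower numbers stand for stronger inhibition and higher numbers for weaker inhibition. Compound 1 has the structure `O=[N+]([O-])c1cn2c(n1)OC(COc1ccc(-c3ccc(C(F)(F)F)cc3)cc1)C2`. In this assay compound 1 gives > 64000 nM, which is a limit of the assay rather than a measured number. Compound 2, with the structure `O=[N+]([O-])c1cn2c(n1)OC(COc1ccc(-c3ccc(OC(F)(F)F)cc3)cc1)C2`, differs from compound 1 by one change, (trifluoromethoxy in place of trifluoromethyl on an aromatic carbon). Compound 2 gives > 64000 nM in this assay, again a limit. The step that the two limits leave unreadable from compound 1 to compound 2 is therefore not readable in size. Compound 3 has the structure `CC1(COc2ccc(-c3ccc(C(F)(F)F)cc3)cn2)Cn2cc([N+](=O)[O-])nc2O1` and a core that is not the same as that of compound 1; the difference between the two cores is not broken down here. Compound 3 gives > 64000 nM in this assay, once more a limit. All three values shown share the same feature, (the limit of > 64000 nM in this assay, at which 3 of the 3 values shown sit).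

Compound 4, not yet measured, has the structure `CC1(COc2ccc(-c3ccc(OC(F)(F)F)cc3)cn2)Cn2cc([N+](=O)[O-])nc2O1`. It is obtained from compound 3 by trifluoromethoxy in place of trifluoromethyl on an aromatic carbon, the same change that leads from compound 1 to compound 2. Compound 4 is expected to show a step that the limit leaves unreadable from compound 3 to compound 4, an expectation that rests on compound 3, whose value > 64000 nM is a limit, and on the unreadable step that the two limits leave unreadable from compound 1 to compound 2 between two limits. For compound 4 the estimate is 80000 nM, with a range from 30000 nM to 250000 nM, and most likely the assay will again report only a limit.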

Compound 4, half-maximal inhibitory concentration: > 64000 nM
Compound 4 ended at the assay's limit (the forecaster's own chance of this, stated with the estimate: 85%); the middle value does not contradict the limit.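

The step from compound 3 to compound 4 cannot be read, since both compounds stop at a limit of this assay rather than giving a measured number. The whole set shares this feature: the limit of > 64000 nM in this assay, at which 4 of the 4 values shown sit. The compounds shown leave open where the true value of each compound lies, and whether trifluoromethoxy in place of trifluoromethyl makes any difference to this read-out.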